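A few compounds are considered here, and "the series" means these few. Any claim that something is new, unique, unknown or untested is made for them only; others in the source may bear on it.

Three compounds built on one shared core were tested in a functional assay on the whole organism (strain albino) for inhibition, with Rattus norvegicus as the target, read by paw edema, with stated times of 1 h and 3 h, at a dose of 20 mmol/kg by the intraperitoneal route (a higher number here means a stronger effect of the compound at the dose given, a lower number a weaker effect), which reports how strongly the swelling of a rat paw is held back at a single dose. Compound 1 `N#CC1=C(NCC(=O)O)N(c2ccccc2)C(=O)N2CCCCC(N3CCCC3)C12` gives 89.2% in this assay. Compound 2 `N#CC1=C(/N=C/c2ccccc2)N(c2ccccc2)C(=O)N2CCCCC(N3CCCC3)C12` gives 84%, and compound 3 `N#CC1=C(/N=C/c2ccc([N+](=O)[O-])cc2)N(c2ccccc2)C(=O)N2CCCCC(N3CCCC3)C12` gives 91.7%. Compound 3 carries the top number of the three, yet the gaps to the other two are small: a number 2.5 percentage points higher from compound 1 to compound 3 (within the scatter), and a number 7.7 percentage points higher from compound 2 to compound 3 (within the scatter). None of these compounds can be called more active than another on these numbers.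

Compound 4 `N#CC1=C(NCC(=O)N2CCCCC2)N(c2ccccc2)C(=O)N2CCCCC(N3CCCC3)C12` differs from compound 3 in one place: a group of 10 heavy atoms (7 carbon, 2 nitrogen, 1 oxygen; one six-membered non-aromatic ring with 1 hetero atom) in place of a group of 11 heavy atoms (7 carbon, 2 nitrogen, 2 oxygen; one six-membered aromatic ring of carbon only), on a double-bonded ring carbon. The earlier steps shown here that bear on this are the two in which the group on the same double-bonded ring carbon was exchanged: a number 5.2 percentage points lower from compound 1 to compound 2 (within the scatter), and a number 2.5 percentage points higher from compound 1 to compound 3 (within the scatter). Both stayed within the scatter although the groups exchanged were quite different in size and makeup. On that basis no step beyond the scatter is expected for the move to compound 4, and the expected step is a number 3.7 percentage points lower from compound 3 to compound 4 (within the scatter). Compound 4 is therefore estimated to give 88% in this assay, with a likely range from 78% to 96%.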

Compound 4, a percentage reported as inhibition, in the whole organism at one dose (the size of the read-out at that dose, not a potency): 53.5%
The estimate for compound 4 lay 34.5 percentage points above the measured number; measured number below the stated range.
By their numbers in this assay, from the lowest: compound 4; then compounds 2, 1 and 3 (each within the scatter of the next).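

In this assay this position turns out not to accept every group: the closest pair, which keeps the chain and swaps only hydroxy for piperidin-1-yl on the carbonyl carbon, shows a number 35.7 percentage points lower from compound 1 to compound 4 (beyond the scatter) in the same study. Compound 2 and compound 3 carry no such hydroxy either, yet the steps of a number 30.5 percentage points lower from compound 2 to compound 4 (beyond the scatter) and a number 38.2 percentage points lower from compound 3 to compound 4 (beyond the scatter) set compound 4 clearly apart from both, so the absence of the carboxylic acid alone does not mark out the low number. Nothing given here offers a reason for this drop.

The compounds shown leave open whether the piperidin-1-yl ring itself matters or whether any capping of the acid on this chain has the same outcome, which a methyl ester, a simple unsubstituted amide or a morpholin-4-yl amide on the same chain would help to separate. They also leave open whether a smaller amine in place of the piperidine ring would hold the number nearer to that of compound 1 at this single dose.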